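The compounds below may be only part of what the source reports. "The series", "measured", "known", "first", "only" and "open" are said of these compounds alone.

Compound 1 `COc1ccc(CNc2nc3cc(N)cc(N)c3nc2-c2ccccc2)cc1OC` gives 26300 nM in a functional assay on UACC-62 cells (Homo sapiens) for inhibition, read by sulforhodamine B assay, with a stated time of 48 h; a lower number here means a stronger inhibitor of growth, a higher number a weaker inhibitor of growth. Compound 2 `Nc1cc(N)c2nc(-c3ccccc3)c(NCc3ccc(F)cc3)nc2c1` gives 29500 nM in this assay, the higher of the two numbers, but the step of a 1.1-fold higher number from compound 1 to compound 2 (0.05 log units; within the scatter) lies within the scatter. Compound 3 `Nc1cc(N)c2nc(-c3ccccc3)c(Sc3ccc(F)cc3)nc2c1` carries (4-fluorophenyl)sulfanyl in place of (4-fluorobenzyl)amino on an aromatic carbon. Among the compounds with values here, the only measured step exchanged one aryl group for another on the same saturated chain and does not touch the link to the core, so no measured step bears on replacing the amino-bearing chain with a sulfur link, and no direction is supported. The step of a 1.0-fold higher number from compound 2 to compound 3 (0.01 log units; within the scatter) is expected to stay within the scatter. Compound 3 is estimated at 30000 nM, between 10000 nM and 90000 nM.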

Compound 3, concentration for total growth inhibition: 31600 nM
The estimate for compound 3 lay 1.1-fold (0.02 log units) below the measured number; the measured number falls inside the stated range.
By their numbers in this assay, from the lowest: compounds 1, 2 and 3 (each within the scatter of the next).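

Placing (4-fluorophenyl)sulfanyl on this aromatic carbon instead of (4-fluorobenzyl)amino gives a 1.1-fold higher number from compound 2 to compound 3 (0.03 log units; within the scatter) in this assay, so this change does not separate the two compounds. The earlier step changed only the aryl group, whereas this one replaces the link to the core, and the number still stays within the scatter. Nothing here gives a measured reason for this result. Still open, going by these compounds, is whether an ether oxygen link or a sulfone link at this position would move the number beyond the scatter.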